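From benzyl to (thiophen-2-yl)methyl: notes on compound 4

The source may hold more compounds than are shown below. What is called first, only, known or untested is meant among the compounds shown, and "the series" means these compounds.

Measured in a physicochemical assay for pharmacokinetics (a higher number here means that the compound lasts longer, a lower number that the compound disappears faster), so far:
compound 1 `CC(NC(=O)N1C(=O)c2ccccc2S1(=O)=O)c1ccccc1` gives > 166 h
compound 2 `COc1cccc(CNC(=O)N2C(=O)c3ccccc3S2(=O)=O)c1` gives > 166 h
compound 3 `O=C(NCc1ccccc1)N1C(=O)c2ccccc2S1(=O)=O` gives > 166 h

Each of these entries is a limit of the assay and not a number. Among the compounds with values here, the series so far shows the limit of > 166 h in this assay, at which 3 of the 3 values shown sit, and nothing finer. Compound 3 stands at > 166 h as a limit, with no number of its own.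

The next compound is compound 4 `O=C(NCc1cccs1)N1C(=O)c2ccccc2S1(=O)=O` with thiophen-2-yl in place of phenyl on a saturated chain carbon bound to an amide-type nitrogen. The measured steps that bear on it are a step that the two limits leave unreadable from compound 1 to compound 3 and a step that the two limits leave unreadable from compound 2 to compound 3 and neither gives a size. Neither of them replaces the phenyl, so no step beyond the scatter is expected, in either direction. The expected step is a step that the limit leaves unreadable from compound 3 to compound 4 and this is only an estimate. Compound 4 is estimated at 200 h with an expected range from 100 h to 400 h and a report as a limit alone is the likely outcome.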

Compound 4, half-life: > 166 h
Compound 4 gave a limit, no number; the forecaster's own chance of this, stated with the estimate: 85%; the middle value is on the limit's open side.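

In this assay, no new step can be read from compound 3 to compound 4 or from compound 2 to compound 4, and the series remains at one limit: the limit of > 166 h in this assay, at which 4 of the 4 values shown sit.

The compounds shown leave open the actual half-life of each compound, and whether phenyl and thiophen-2-yl differ at all.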